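A fluoro swap at the assay limit

The compounds below may be only part of what the source reports. "The series", "measured", "known", "first", "only" and "open" are said of these compounds alone.

Of the compounds shown here, three have been measured in a functional assay on HepG2 cells (Homo sapiens) for cytotoxicity, read by MTT assay, with a stated time of 24 h; on this read-out lower numbers stand for stronger inhibition and higher numbers for weaker inhibition. Compound 1 `Nc1cccn2cc(Cc3ccccc3)c(=O)nc12` gives 131000 nM. Compound 2 `O=c1nc2ccc(Br)cn2cc1Cc1ccccc1` is reported only as a limit, > 1000000 nM. Compound 3 `O=c1nc2ccccn2cc1Cc1ccc(F)cc1` is also reported only as a limit, > 1000000 nM, so no number fixes where it stands. The set thus shows (the limit of > 1000000 nM in this assay, at which 2 of the 3 values shown sit).

Compound 4 `O=c1nc2ccccn2cc1Cc1ccccc1` has hydrogen in place of fluoro on an aromatic carbon of a six-membered aromatic ring of carbon only, para to a large group: hydrogen in place of fluoro on an aromatic carbon. For the measured compounds named here, no measured pair in the set isolates a single change, so the expectation rests on little. In this assay, no step beyond the scatter is expected in either direction, given that compound 3 has the limit > 1000000 nM. The expected step is a number no higher from compound 3 to compound 4 (the limit leaves the size open). For compound 4 the estimated value is 1000000 nM, with an expected range from 300000 nM to 3000000 nM.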

Compound 4, half-maximal inhibitory concentration: > 1000000 nM
Compound 4 ended at the assay's limit (the forecaster's own chance of this, stated with the estimate: 55%); the middle value sits exactly at the limit.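

With compound 4 in hand, the amino group of compound 1 can be read as a single change on the shared core in this assay: swapping the amino group for hydrogen gives an at least 7.6-fold higher number from compound 1 to compound 4 (0.88 log units; beyond the scatter). For the compounds shown here, this is the first single change in the set that can be given a size, and compound 1 remains the only compound with a value that is not a limit. The steps to compound 4 from compound 2 and from compound 3 cannot be read, and the set now sits largely at one limit: the limit of > 1000000 nM in this assay, at which 3 of the 4 values shown sit.

Going by these compounds, whether fluoro or bromo changes the number at all stays open, with both steps unreadable. On these data alone, it also stays open whether a hydroxyl group or a methylamino group in the place of the amino group of compound 1 would give a measurable value.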